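The source may report more compounds than this note shows. Statements on the series, on what has been measured and on what is new or still open speak of the compounds shown alone.

Measured in an ADME assay on cells (Hepatocyte, Rattus norvegicus) for metabolic stability, using equilibrium dialysis; a higher number here means faster removal of the compound, a lower number slower removal:

compound 1 `CC(=O)N[C@@H]1CCC[C@H](C(=O)Nc2cc(-c3cnc(C)n3C(C)C)ccn2)C1` — 7.4 uL/min
compound 2 `CC(=O)N[C@@H]1CCC[C@H](C(=O)Nc2cc(-c3cnn4c3CCCCC4)c(Cl)cn2)C1` — 51 uL/min
compound 3 `CC(=O)N[C@@H]1CCC[C@H](C(=O)Nc2cc(-c3cnn4c3CC(C)(C)CC4)ccn2)C1` — 35 uL/min

Compound 3 stands second highest of the three numbers in this assay. Its nearest neighbour is compound 2, whose number is higher but within the scatter, so no order between the two can be claimed. Its furthest neighbour is compound 1, whose number is lower by a gap beyond the scatter; compound 1 also differs from compound 3 in the bicyclic part, so the comparison does not isolate one change.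

Compound 4 `CC(=O)N[C@@H]1CCC[C@H](C(=O)Nc2cc(-c3cnn4c3CC(C)(C)CC4)c(F)cn2)C1` is not yet measured. It differs from compound 3 in one place: fluoro in place of hydrogen on an aromatic carbon

Within the data shown here, no step between measured compounds isolates this change, so the expectation rests on compound 3 alone. A single fluoro entering for hydrogen is expected to move the number in this assay by no more than the scatter, with no clear direction. Compound 4 is therefore expected to give 32 uL/min, with a range of 16 uL/min to 65 uL/min. The step of a 1.1-fold lower number from compound 3 to compound 4 (0.04 log units; within the scatter) is estimated to lie within the scatter.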

Compound 4, intrinsic clearance in a liver preparation (reported as CLH), per the amount of preparation that the assay uses in the Hepatocyte assay: 42 uL/min
Estimate against measurement, compound 4: 1.3-fold (0.12 log units) below, and the stated range covers the measured number.
By their numbers in the Hepatocyte assay, from the lowest: compound 1; then compounds 3, 4 and 2 (each within the scatter of the next).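

Among these compounds, in the Hepatocyte assay the only step that isolates this position reads a 1.2-fold higher number from compound 3 to compound 4 (0.08 log units; within the scatter), so fluoro in place of hydrogen on this aromatic carbon shows no readable effect on removal of the compound. In a physicochemical assay for solubility, in phosphate buffer, at pH 7.4 (on this read-out higher numbers stand for higher solubility and lower numbers for lower solubility), compound 3 gives 640000 nM and compound 4 gives 160000 nM. The same change therefore separates the two compounds on solubility alone, a difference the earlier compounds could not show: the measured solubility of compound 3, 640000 nM, and of compound 4, 160000 nM, a 4.0-fold lower number (0.60 log units; beyond the scatter)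

Among the compounds shown here, only this one pair carries the change, so nothing here extends it to the core of compound 1 or to any other compound. On these data alone, whether a different group on this aromatic carbon, such as an amine or methoxy, would leave the number in the Hepatocyte assay within the scatter while keeping the number in the physicochemical assay nearer that of compound 3 remains open.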